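The source may hold more compounds than are shown below. What is called first, only, known or untested is meant among the compounds shown, and "the series" means these compounds.

Measured so far in a functional assay on A549 cells (Homo sapiens) for cytotoxicity, read by MTT assay, with a stated time of 72 h; on this read-out higher numbers stand for weaker inhibition and lower numbers for stronger inhibition:
compound 1, `COc1ccc(S(=O)(=O)c2nc3ccccc3nc2N2CCCC2)cc1`: > 50000 nM
compound 2, `O=S(=O)(c1ccc(Br)cc1)c1nc2ccccc2nc1N1CCCC1`: > 50000 nM
compound 3, `COc1ccc(S(=O)(=O)c2nc3ccccc3nc2N2CCCC(O)C2)cc1`: 2180 nM

The value of compound 1 is a limit of the assay and not a number. The value of compound 2 is likewise a limit. Two of the three values sit at the limit of > 50000 nM in this assay, at which 2 of the 3 values shown sit. Among the measured compounds shown here, compound 3 gives the only number in the set.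

Compound 2 differs from compound 1 by bromo in place of methoxy on an aromatic carbon. The resulting step, a step that the two limits leave unreadable from compound 1 to compound 2, has no readable size. Compound 3 differs from compound 1 by 3-hydroxypiperidin-1-yl in place of pyrrolidin-1-yl on an aromatic carbon, and here the step is an at least 22-fold lower number from compound 1 to compound 3 (1.36 log units; beyond the scatter), a large and readable one.

Compound 4, `O=S(=O)(c1ccc(Br)cc1)c1nc2ccccc2nc1N1CCCC(O)C1`, is not yet measured. It differs from compound 3 by bromo in place of methoxy on an aromatic carbon. The place lines of this change and of the change from compound 1 to compound 2 agree word for word, so it is the same change, made on a different core; how the cores differ is given by 3-hydroxypiperidin-1-yl in place of pyrrolidin-1-yl on an aromatic carbon above. For the measured compounds named here, the only measured instance of the change is a step that the two limits leave unreadable from compound 1 to compound 2, which leaves its size unknown, so the expected step is taken as close to none and is a 1.4-fold higher number from compound 3 to compound 4 (0.14 log units; within the scatter). The expectation rests on compound 3 at 2180 nM as the starting point. Compound 4 is expected near 3000 nM, with a wide span from 700 nM to 25000 nM.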

Compound 4, half-maximal inhibitory concentration: 2100 nM
Compound 4: the middle estimate sits 1.4-fold (0.15 log units) above what was measured; low and high end bracket the measured number.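

In this assay, bromo in place of methoxy on the core of compound 3 gives a 1.0-fold lower number from compound 3 to compound 4 (0.02 log units; within the scatter), which is the only readable size for this change, as its step on the pyrrolidin-1-yl core cannot be read. With bromo in place, 3-hydroxypiperidin-1-yl in place of pyrrolidin-1-yl gives an at least 23-fold lower number from compound 2 to compound 4 (1.37 log units; beyond the scatter), so the large step seen with methoxy also appears with bromo, and the amine change carries across the two aryl groups in direction and at a large size: the same change on two cores in this assay, an at least 22-fold lower number (1.36 log units; beyond the scatter) from compound 1 to compound 3 and an at least 23-fold lower number (1.37 log units; beyond the scatter) from compound 2 to compound 4; the limit leaves it open whether they differ. This does not show that the bromo change is silent on every core, nor does it fix the true size of either amine step, as compound 1 and compound 2 are limits and not numbers: the limit of > 50000 nM in this assay, at which 2 of the 4 values shown sit.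

The compounds shown leave open whether the step comes from the hydroxyl group, from the larger ring or from both, which a piperidin-1-yl compound and a 3-hydroxypyrrolidin-1-yl compound would separate. They also leave open whether the flat result on the aryl group extends beyond methoxy and bromo, for instance to a nitrile or a carboxylic acid at the same place on the core of compound 3.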